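Swapping vinyl for an aryl ester: cytotoxicity outlook

A few compounds are considered here, and "the series" means these few. Any claim that something is new, unique, unknown or untested is made for them only; others in the source may bear on it.

Working notes on compound 1 `CC(C)C(=O)OC1CCC(CN2CCN(c3cc(=O)c4cc(C(F)(F)F)cc([N+](=O)[O-])c4s3)CC2)CC1`, compound 2 `O=C(NC1CCC(CN2CCN(c3cc(=O)c4cc(C(F)(F)F)cc([N+](=O)[O-])c4s3)CC2)CC1)c1ccccc1`, compound 3 `C=CC(=O)OC1CCC(CN2CCN(c3cc(=O)c4cc(C(F)(F)F)cc([N+](=O)[O-])c4s3)CC2)CC1` and compound 4 `COc1cccc(C(=O)OC2CCC(CN3CCN(c4cc(=O)c5cc(C(F)(F)F)cc([N+](=O)[O-])c5s4)CC3)CC2)c1`, which share one core.

In an ADME assay on Vero cells (Chlorocebus sabaeus) for cytotoxicity, read by MTT assay, with a stated time of 48 h (a lower number here means a stronger inhibitor, a higher number a weaker inhibitor), compound 3 gives > 64 ug/mL, which is a limit and not a number. Compound 1 gives > 64 ug/mL, also a limit. Compound 2 gives a true number, 44.3 ug/mL.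

Compound 4 carries 3-methoxyphenyl in place of vinyl on a carbonyl carbon.

Within the data shown here, the closest precedent is a swap on that same carbonyl carbon, a step that the two limits leave unreadable from compound 1 to compound 3. The benzamido swap gives an at least 1.4-fold lower number from compound 1 to compound 2 (0.15 log units; that floor lies within the scatter), and the return to an ester gives an at least 1.4-fold higher number from compound 2 to compound 3 (0.15 log units; that floor lies within the scatter). Neither floor shows a change beyond the scatter, so no clear shift is expected in this assay, though a modest move towards a lower number is possible. The expected size is an at least 1.1-fold lower number from compound 3 to compound 4 (0.06 log units; that floor lies within the scatter). A report as a limit remains quite possible.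

For compound 4 the estimate is 55 ug/mL, with an expected range of 28 ug/mL to 100 ug/mL.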

Compound 4, half-maximal inhibitory concentration: > 64 ug/mL
Compound 4: no number, only a limit; the forecaster's own chance of this, stated with the estimate: 45%; middle value at least 1.1-fold (0.06 log units) from the limit.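

In this assay compound 4 gives > 64 ug/mL, which is a limit and not a number. On this carbonyl carbon, 3-methoxyphenyl, with one six-membered aromatic ring and 8 heavy atoms against the 2 of vinyl, leaves the ester reported as a limit, as with the vinyl and isopropyl esters, so a larger aryl group does not by itself bring a true number. The swap back from benzamido gives an at least 1.4-fold higher number from compound 2 to compound 4 (0.15 log units; that floor lies within the scatter), while the steps among the three esters cannot be read: the limit of > 64 ug/mL in this assay, at which 3 of the 4 values shown sit.

Still open, on these data alone, is where any of these esters would give a true number in this assay, since the limits hide their size. Also open, as far as these compounds go, is whether an amine or a carboxylic acid in place of 3-methoxyphenyl on this carbonyl carbon would stay at the limit.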